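This account rests on a few compounds, and the source may have more. Where it says the series, first, only, none or still open, it means among the compounds named here.

In a functional assay on HCT-116 cells (Homo sapiens), read by MTT assay, with a stated time of 72 h (a higher number here means a weaker inhibitor, a lower number a stronger inhibitor), compound 1 (`Cc1ncnc2c1c(-c1cccs1)cn2[C@@H]1O[C@H](CO)[C@@H](O)[C@H]1O`) gives > 20000 nM as a limit and not a number. Compound 2 (`Nc1nc(N)c2c(-c3ccco3)cn([C@@H]3O[C@H](CO)[C@@H](O)[C@H]3O)c2n1`) gives > 20000 nM as a limit too. Compound 3 (`Cc1nc(N)c2c(-c3ccco3)cn([C@@H]3O[C@H](CO)[C@@H](O)[C@H]3O)c2n1`) gives > 20000 nM as a limit as well, so it has no number of its own. Among the compounds with values here, the series so far offers only the limit of > 20000 nM in this assay, at which 3 of the 3 values shown sit, as evidence. Compound 4 (`Cc1nc(N)c2c(-c3cc4ccccc4o3)cn([C@@H]3O[C@H](CO)[C@@H](O)[C@H]3O)c2n1`) carries 1-benzofuran-2-yl in place of furan-2-yl on an aromatic carbon. Within the data shown here, the one measured step is a step that the two limits leave unreadable from compound 2 to compound 3 and it involves another position, so no size or direction carries over to this change. The expected change is a number no higher from compound 3 to compound 4 (the limit leaves the size open) in this assay and remains uncertain. Compound 4 is estimated at 20000 nM with an expected range from 5000 nM to 40000 nM in this estimate.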

Compound 4, half-maximal inhibitory concentration: > 20000 nM
Compound 4: only a limit was reported; the forecaster's own chance of this, stated with the estimate: 70%; the middle value sits exactly at the limit.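

Compound 3 and compound 4 both sit at a limit and not at a number, so no step can be read between them: the limit of > 20000 nM in this assay, at which 4 of the 4 values shown sit.

The compounds shown leave open the size and direction of the change from furan-2-yl to 1-benzofuran-2-yl.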